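This account rests on a few compounds, and the source may have more. Where it says the series, first, only, none or still open, it means among the compounds named here.

Measured compounds:
- Compound 1 `CCc1cccc(NC(=O)c2cccc(/C=C3\CC(=O)N(c4ccccc4)C3=O)c2)c1`: 81200 nM
- Compound 2 `CCCCCN1C(=O)C/C(=C\c2cccc(C(=O)Nc3cccc(CC)c3)c2)C1=O`: 75300 nM

In an ADME assay on HCT-116 cells (Homo sapiens) for cytotoxicity, read by MTT assay, with a stated time of 72 h (on this read-out lower numbers stand for stronger inhibition and higher numbers for weaker inhibition), compound 1 gives 81200 nM. For the measured compounds named here, compound 2, the only other measured compound, gives 75300 nM; the two numbers lie within the scatter of each other, so compound 1 stands neither apart from nor ordered against compound 2. Going by the values given here, the one measured step, a 1.1-fold lower number from compound 1 to compound 2 (0.03 log units; within the scatter), concerns pentyl in place of phenyl on an amide-type nitrogen in a ring and reports no change beyond the scatter.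

Compound 3 `O=C(Nc1ccc(F)cc1)c1cccc(/C=C2\CC(=O)N(c3ccccc3)C2=O)c1` differs from compound 1 at a different place: 4-fluorophenyl in place of 3-ethylphenyl on an amide-type nitrogen. Among the compounds with values here, no measured step touches the amide-type nitrogen whose other neighbour is a carbonyl carbon, so nothing in the data speaks to how exchanging 3-ethylphenyl for 4-fluorophenyl there moves the read-out. Within the data shown here, the only available step, a 1.1-fold lower number from compound 1 to compound 2 (0.03 log units; within the scatter), shows that the single change tested so far left the number within the scatter. On that slender basis, compound 3 is expected to show a 1.0-fold lower number from compound 1 to compound 3 (0.01 log units; within the scatter), a step not beyond the scatter. Compound 3 is therefore estimated at 80000 nM, with a range from 30000 nM to 200000 nM.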

Compound 3, half-maximal inhibitory concentration: > 100000 nM
Compound 3: a limit, no number (the forecaster's own chance of this, stated with the estimate: 15%); at least 1.2-fold (0.09 log units) between middle value and limit.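

In this assay compound 3 gives > 100000 nM, which is a limit of the assay and not a number. Exchanging 3-ethylphenyl for 4-fluorophenyl on the amide-type nitrogen whose other neighbour is a carbonyl carbon gives an at least 1.2-fold higher number from compound 1 to compound 3 (0.09 log units; that floor lies within the scatter), the first measured information about this place, as the earlier step concerned only the nitrogen in the ring. This step has a floor but no size, so it does not establish a change beyond the scatter, and the read-out cannot show how far the true value lies past the limit: the limit of > 100000 nM in this assay, at which 1 of the 3 values shown sits.

The compounds shown leave open whether the loss of the ethyl group or the arrival of the fluorine matters at this nitrogen, since the two are exchanged together here, and a ring carrying only one of the two changes would be needed to separate them. Also open, from the compounds shown here alone, is how this amide-type nitrogen would respond to a 4-methoxyphenyl group or to an aromatic ring carrying an amine or a carboxylic acid, and whether a longer chain than pentyl on the ring nitrogen would move the number.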